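The source may report more compounds than this note shows. Statements on the series, on what has been measured and on what is new or still open speak of the compounds shown alone.

Values in an ADME assay on HepG2 cells (Homo sapiens) for cytotoxicity, read by MTT assay, with a stated time of 72 h; a higher number here means that more compound is tolerated, a lower number that less compound is tolerated:
- compound 1 `O=[N+]([O-])c1c(CS(=O)(=O)c2ccccc2)nc2c(C#Cc3ccc(F)cc3)cc(Cl)cn12`: > 3900 nM
- compound 2 `O=[N+]([O-])c1c(CS(=O)(=O)c2ccccc2)nc2c(C#CCOc3ccccc3)cc(Cl)cn12`: 8400 nM
- compound 3 `CC(O)(C#Cc1cc(Cl)cn2c([N+](=O)[O-])c(CS(=O)(=O)c3ccccc3)nc12)c1ccccc1`: 18800 nM

Compound 1 gives > 3900 nM, which is a limit and not a number. Compound 3 holds the higher of the two true numbers, at 18800 nM. Compound 4 `O=[N+]([O-])c1c(CS(=O)(=O)c2ccccc2)nc2c(C#CC3(O)CCCCC3)cc(Cl)cn12` differs from compound 3 on the triple-bonded carbon: 1-hydroxycyclohexyl in place of 1-hydroxy-1-phenylethyl on a triple-bonded carbon. Among the measured compounds shown here, the steps from compound 1 have no readable size, so only one measured step at this place bears on the change: a 2.2-fold higher number from compound 2 to compound 3 (0.35 log units; beyond the scatter). That step is modest, and it gives no direction for this change, so no step beyond the scatter is expected in this assay. The estimate is a 1.1-fold lower number from compound 3 to compound 4 (0.04 log units; within the scatter), as an expected step. For compound 4 the expected value is 17000 nM, with an estimated range of 8000 nM to 40000 nM.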

Compound 4, half-maximal cytotoxic concentration: > 25000 nM
Compound 4 gave a limit, no number; the forecaster's own chance of this, stated with the estimate: 20%; middle value at least 1.4-fold (0.16 log units) from the limit.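

In this assay compound 4 gives a limit, not a number: the limit of > 25000 nM in this assay, at which 1 of the 4 values shown sits. On this triple-bonded carbon, a tertiary alcohol carrying no aromatic ring is tolerated without any readable loss, with an at least 1.3-fold higher number from compound 3 to compound 4 (0.12 log units; that floor lies within the scatter), whose floor lies within the scatter, and with an at least 2.9-fold higher number from compound 2 to compound 4 (0.47 log units; beyond the scatter), which is beyond it. The step between compound 1 and compound 4 cannot be read.

From the compounds shown here alone, the true size of the step to 1-hydroxycyclohexyl remains open. So does the reading in this assay with an amine or a carboxylic acid in place of the hydroxyl on this ring.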